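Working notes: from compound 3 to compound 4

The source may report more compounds than this note shows. Statements on the series, on what has been measured and on what is new or still open speak of the compounds shown alone.

In a functional assay on HeLa cells (Homo sapiens) for antiproliferative activity, read by CCK-8 assay, with a stated time of 72 h (a higher number here means a weaker inhibitor, a lower number a stronger inhibitor), compound 1 `Cc1ccc(Nc2nc(Cl)nc3c2ncn3Cc2ccc(C(=O)Nc3ccccc3N)cc2)cc1` gives 1050 nM and compound 2 `CC1CCN(c2nc(Cl)nc3c2ncn3Cc2ccc(C(=O)Nc3ccccc3N)cc2)CC1` gives 4500 nM. Compound 3 `Nc1ccccc1NC(=O)c1ccc(Cn2cnc3c(Nc4cccc(Cl)c4)nc(Cl)nc32)cc1` gives 11300 nM, the highest of the three numbers, which makes it the weakest inhibitor so far. Both steps to it lie beyond the scatter: an 11-fold higher number from compound 1 to compound 3 (1.03 log units; beyond the scatter) and a 2.5-fold higher number from compound 2 to compound 3 (0.40 log units; beyond the scatter).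

Compound 4 `CN1CCN(c2nc(Cl)nc3c2ncn3Cc2ccc(C(=O)Nc3ccccc3N)cc2)CC1` changes one place: 4-methylpiperazin-1-yl in place of (3-chlorophenyl)amino on an aromatic carbon. The 4-methylpiperazin-1-yl sits on an aromatic carbon, next to the ring nitrogen.

Among the measured compounds shown here, no compound carrying this group has been measured. The nearest guide is compound 2, which holds 4-methylpiperidin-1-yl at the same place, and its step of a 2.5-fold higher number from compound 2 to compound 3 (0.40 log units; beyond the scatter) is read here in reverse. The step of a 4.3-fold higher number from compound 1 to compound 2 (0.63 log units; beyond the scatter) shows that a saturated ring at this place does not always give the lower number, as compound 1 goes against that trend. Its (4-methylphenyl)amino group gives a lower number than the ring of compound 2.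

A modest step toward a lower number is expected, estimated as a 2.5-fold lower number from compound 3 to compound 4 (0.40 log units; beyond the scatter). For compound 4 the estimated value is 4500 nM, with an expected range of 1500 nM to 12000 nM.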

Compound 4, half-maximal inhibitory concentration: 1170 nM
The estimate for compound 4 lay 3.8-fold (0.59 log units) above the measured number, outside the stated range (below it).
By their numbers in this assay, from the lowest: compounds 1 and 4 (each within the scatter of the next); then compound 2; then compound 3.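

In this assay, among the compounds shown here, the step from 4-methylpiperidin-1-yl to 4-methylpiperazin-1-yl gives a 3.8-fold lower number from compound 2 to compound 4 (0.59 log units; beyond the scatter), so two six-membered non-aromatic rings of similar size are not interchangeable at this position, and the earlier compounds could not show this difference between saturated rings. The same group in place of (3-chlorophenyl)amino gives a 9.7-fold lower number from compound 3 to compound 4 (0.98 log units; beyond the scatter), whereas in place of (4-methylphenyl)amino it gives a 1.1-fold higher number from compound 1 to compound 4 (0.05 log units; within the scatter), so a non-aromatic ring and an arylamino group can match each other here, and the outcome of the swap depends on which arylamino group it is compared with. No measurement at hand bears on what lies behind the size of these steps.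

The compounds shown leave open whether the gain from the piperazine depends on its methyl group, which a piperazin-1-yl ring without that methyl or a morpholin-4-yl ring at the same aromatic carbon would test. They also leave open whether the pattern holds when the chloro group on the shared core is exchanged for an amine, since all four compounds carry that chloro group.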